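A few compounds are considered here, and "the series" means these few. Any claim that something is new, unique, unknown or untested is made for them only; others in the source may bear on it.

Working notes on the series. Among the compounds with values here, compound 1 `CCOC(=O)C1=C(Nc2ccccc2)S/C(=C\c2ccc[nH]2)C1=O` is the reference: in a functional assay on JAR cells (Homo sapiens) for inhibition, read by MTT assay, with a stated time of 72 h, tested at 10 uM (on this read-out lower numbers stand for less inhibition and higher numbers for more inhibition at the one concentration tested (going by the name of the read-out)), compound 1 gives 49.2%, the only outright number among the three measured compounds. Compound 2 `CCOC(=O)C1=C(Nc2ccc(C)cc2)S/C(=C\c2ccc[nH]2)C1=O` carries a methyl in place of hydrogen on an aromatic carbon; in this assay compound 2 gives < 10%, a limit of the assay and not a number. Compound 3 `CCOC(=O)C1=C(Nc2ccc(CC)cc2)S/C(=C\c2ccc[nH]2)C1=O` carries an ethyl in place of hydrogen on an aromatic carbon; in this assay compound 3 gives < 10%, again a limit. The step of a number at least 39.2 percentage points lower from compound 1 to compound 2 (beyond the scatter) and the step of a number at least 39.2 percentage points lower from compound 1 to compound 3 (beyond the scatter) are both large losses beyond the scatter, while the step that the two limits leave unreadable from compound 2 to compound 3 stays unreadable, both values sitting at the limit of < 10% in this assay, at which 2 of the 3 values shown sit.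

Compound 4 `CCOC(=O)C1=C(Nc2ccccc2)S/C(=C\c2ccc(C(=O)OCC)[nH]2)C1=O` is not yet measured. Relative to compound 1 the change is ethoxycarbonyl in place of hydrogen on an aromatic carbon. Within the data shown here, the measured changes sit elsewhere in the structure, and none concerns the five-membered aromatic ring with one nitrogen, so no measured step bears directly on this change. The expected size of a number 14.2 percentage points lower from compound 1 to compound 4 (beyond the scatter) therefore rests only on compound 1 standing at 49.2% and on each earlier alteration having lost inhibition. Compound 4 is estimated at 35%, with a range from 10% to 60%.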

Compound 4, a percentage reported as inhibition, at one concentration (the size of the read-out at that concentration, not a potency): 60.1%
Estimate against measurement, compound 4: 25.1 percentage points below; measured number above the stated range.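

In this assay, the five-membered aromatic ring with 1 nitrogen accepts a substituent of 5 heavy atoms on an aromatic carbon next to the ring nitrogen, and ethoxycarbonyl there gives a number 10.9 percentage points higher from compound 1 to compound 4 (beyond the scatter). This is the first addition in the series to raise the number, whereas the methyl and ethyl additions elsewhere in the structure both gave large losses, so among these compounds an addition to the core of compound 1 does not lower inhibition at every place. No measured property in the data bears on the origin of this modest gain.

Ethoxycarbonyl is the only group shown at this position, so it remains open whether a carboxylic acid, an amide or a plain methyl at the same carbon would keep, raise or lose the gain, and whether the gain extends to concentrations other than the one tested. On these data alone, the step between the two compounds at the limit cannot be read, and it also remains open whether ethoxycarbonyl on this ring would restore inhibition when combined with a methyl or ethyl substituent elsewhere.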